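A few compounds are considered here, and "the series" means these few. Any claim that something is new, unique, unknown or untested is made for them only; others in the source may bear on it.

Measured so far in a functional assay on HCT-116 cells (Homo sapiens) for antiproliferative activity, read by WST assay, with a stated time of 72 h; on this read-out lower numbers stand for stronger inhibition of growth and higher numbers for weaker inhibition of growth 
- compound 1 `O=C(NO)c1cnc(N2C[C@@H]3[C@H](C2)[C@H]3NCc2ccc(F)cc2)nc1` gives 380 nM 
- compound 2 `O=C(NO)c1cnc(N2C[C@@H]3[C@H](C2)[C@H]3NCc2ccc(Br)cc2)nc1` gives 250 nM 

Among the measured compounds shown here, compound 2 lies within the scatter of compound 1, its only neighbour, so the two cannot be ranked. The gap between them is a 1.5-fold lower number from compound 1 to compound 2 (0.18 log units; within the scatter) and nothing more.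

The open case is compound 3 `O=C(NO)c1cnc(N2C[C@@H]3[C@H](C2)[C@H]3NCc2ccc(C(F)(F)F)cc2)nc1` which has trifluoromethyl in place of bromo on an aromatic carbon with the rest of compound 2 unchanged. For the measured compounds named here, only one measured step bears on this change, the exchange of halogens a 1.5-fold lower number from compound 1 to compound 2 (0.18 log units; within the scatter) at the same place. Going by the values given here, no compound yet carries trifluoromethyl, so this single step is thin support. On that basis, no step beyond the scatter is expected in this assay and no direction can be assigned. The estimate corresponds to an expected 1.2-fold higher number from compound 2 to compound 3 (0.08 log units; within the scatter) and so stays inside the scatter. Compound 3 is expected at 300 nM in this assay with 130 nM as the estimated lower end and 680 nM as the upper end.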

Compound 3, concentration for 50% growth inhibition: 700 nM
For compound 3 the middle estimate is 2.3-fold (0.37 log units) below the measured one; the whole stated range lies below it.
By their numbers in this assay, from the lowest: compounds 2, 1 and 3 (each within the scatter of the next, the first and the last beyond it).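

In this assay this place, on an aromatic carbon para to a large group, now gives its first step beyond the scatter: a 2.8-fold higher number from compound 2 to compound 3 (0.45 log units; beyond the scatter) (modest) for trifluoromethyl in place of bromo. The fluoro-to-bromo exchange did not show that the substituent at this place could separate two compounds, but this change does, so the place is not indifferent to what sits there. The same group in place of fluoro gives a 1.8-fold higher number from compound 1 to compound 3 (0.27 log units; within the scatter) and stays within the scatter, so the separation holds only against compound 2, compound 1 cannot be ranked against either neighbour, and no trend across the three groups can be drawn, while nothing available explains the step.

The compounds shown cover only bromo, fluoro and trifluoromethyl at this one place, on one shared core, so it remains open whether a methoxy, an amine or a carboxylic acid there would fall inside the same range or outside it. Also open, on these data alone, is whether the step seen with trifluoromethyl would recur if the carbon chain linking this aromatic ring to the core were longer.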